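This account rests on a few compounds, and the source may have more. Where it says the series, first, only, none or still open, it means among the compounds named here.

Two compounds of the series carry a measurement in a functional assay on KYSE-450 cells (Homo sapiens) for inhibition, read by MTT assay, with a stated time of 48 h; a higher number here means a weaker inhibitor, a lower number a stronger inhibitor. Compound 1 `C#CC(=O)N(Cc1ccc(OC)c(O)c1)c1cc(OC)c(OC)c(OC)c1` gives 570 nM and stands as the lower of the two numbers. Compound 2 `COc1ccc(CNc2cc(OC)c(OC)c(OC)c2)cc1[N+](=O)[O-]` gives 16800 nM, and the gap between the two lies beyond the scatter. The two structures differ in more than one place, so only the two values themselves are noted, with no single change to attach the gap to.

Compound 3 `COc1ccc(CN(C(=O)/C=C/CBr)c2cc(OC)c(OC)c(OC)c2)cc1O` has not yet been measured in this assay. It differs from compound 1 in one place: 3-bromoprop-1-en-1-yl in place of ethynyl on a carbonyl carbon. Within the data shown here, no pair among the measured compounds isolates this change, since compound 2 differs from compound 1 elsewhere as well, so there is no measured step to lean on. The expectation is therefore held loose: the step of a 1.4-fold higher number from compound 1 to compound 3 (0.15 log units; within the scatter) is expected to be small, most likely within the scatter, with no direction asserted. Compound 3 is expected to give about 800 nM in this assay, with a likely range from 250 nM to 2500 nM.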

Compound 3, half-maximal inhibitory concentration: 100 nM
Estimate against measurement, compound 3: 8.0-fold (0.90 log units) above; measured number outside the range, below it.
By their numbers in this assay, from the lowest: compound 3; then compound 1; then compound 2.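

In this assay, among these compounds, the group on the carbonyl carbon, whose other neighbour is the amide-type nitrogen, proves able to move the number on its own: 3-bromoprop-1-en-1-yl in place of ethynyl gives a 5.7-fold lower number from compound 1 to compound 3 (0.76 log units; beyond the scatter) and this is the first gap that can be tied to a single change. The position accepts the larger group, with 4 heavy atoms entering for 2 and a double bond for a triple bond, and the number falls rather than rises while the rest of the core of compound 1 stays the same. No measurement at hand identifies which feature of the entering group carries the step, and no supporting data bear on its cause.

The compounds shown leave open whether the bromine is needed, as a plain prop-1-en-1-yl group, or the same chain ending in chlorine or in a dimethylamino group, would separate the halogen from the double bond. Also open, on these data alone, is whether the step carries over to a core bearing a nitro group in place of the hydroxyl, as in compound 2.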